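Swapping a Carbonate for an Ester on an Ethyl Chain

The source may report more compounds than this note shows. Statements on the series, on what has been measured and on what is new or still open speak of the compounds shown alone.

Of the compounds shown here, three sharing one core have been tested in a functional assay on the whole organism (strain Sprague-Dawley) for inhibition, with Rattus norvegicus as the target, with a stated time of 0.5 h, at a dose of 5 mg/kg by the oral route; a lower number here means less inhibition, a higher number more inhibition at the dose given (going by the name of the read-out). Compound 1, `CCCSc1nc(N[C@@H]2C[C@H]2c2ccc(F)c(F)c2)c2nnn([C@@H]3C[C@H](OCCOC(=O)CCC)[C@@H](O)[C@H]3O)c2n1`, gives "not active" (no number reported). Compound 2, `CCCSc1nc(N[C@@H]2C[C@H]2c2ccc(F)c(F)c2)c2nnn([C@@H]3C[C@H](OCCOC(=O)c4cccnc4)[C@@H](O)[C@H]3O)c2n1`, also gives "not active" (no number reported). Going by the values given here, only compound 3, `CCCSc1nc(N[C@@H]2C[C@H]2c2ccc(F)c(F)c2)c2nnn([C@@H]3C[C@H](OC(=O)OCC(C)C)[C@@H](O)[C@H]3O)c2n1`, comes with a figure: in this assay compound 3 gives 13.2%, a low degree of inhibition and the only number in the set, so it stands alone rather than above or below any measured neighbour. Among the compounds with values here, no two of the measured compounds differ from one another in a single place, so no single step between them can be drawn.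

Compound 4, `CCCSc1nc(N[C@@H]2C[C@H]2c2ccc(F)c(F)c2)c2nnn([C@@H]3C[C@H](OCCOC(=O)C(C)(C)C)[C@@H](O)[C@H]3O)c2n1`, differs from compound 3 at one spot: 2-(((tert-butyl)carbonyl)oxy)ethyl in place of isobutoxycarbonyl on an oxygen on a saturated carbon. Compound 4 thereby resembles compound 1 and compound 2, which also carry an ester hung from a chain on that oxygen and gave no number, more than it resembles compound 3. The expectation for compound 4 is therefore a small downward step, a number 8.2 percentage points lower from compound 3 to compound 4 (within the scatter), likely staying within the usual scatter. The estimate for compound 4 in this assay is 5%, with a range from 0% to 18%. A report of no number at all, as for compound 1 and compound 2, is also quite possible.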

Compound 4, a percentage reported as inhibition, in the whole organism at one dose (the size of the read-out at that dose, not a potency): 46.1%
Compound 4: middle estimate off by 41.1 percentage points, on the low side; measured number above the stated range.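

At the oxygen on a saturated carbon, the group can matter a great deal in this assay: 2-(((tert-butyl)carbonyl)oxy)ethyl in place of isobutoxycarbonyl brings a number 32.9 percentage points higher from compound 3 to compound 4 (beyond the scatter) and so marks this position as sensitive to what is attached there. An ester hung from a chain on this oxygen does not by itself rule out a numerical result, as compound 1 gives "not active" (no number reported) and compound 2 gives "not active" (no number reported) while compound 4, which also carries such an ester, gives a number. No measurement available here accounts for the rise.

The tert-butyl end of the ester may or may not be what sets compound 4 apart from compound 1 and compound 2. As far as these compounds go, how a plain 2-hydroxyethyl chain or a chain ending in an amine would read on this oxygen also remains open.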